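A few compounds are considered here, and "the series" means these few. Any claim that something is new, unique, unknown or untested is made for them only; others in the source may bear on it.

Measured so far:
Compound 1, `CNc1nc(-c2cc(OC)c(OC)c(OC)c2)c(-c2ccc(C)cc2)s1`, gives 18.1 nM in a functional assay on HL-60 cells (Homo sapiens) for antiproliferative activity, read by MTT assay, with a stated time of 72 h; a higher number here means a weaker inhibitor, a lower number a stronger inhibitor.
Compound 2, `CNc1nc(-c2cc(OC)c(OC)c(OC)c2)c(-c2ccc(C(F)(F)F)cc2)s1`, gives 3170 nM.
Compound 3, `COc1cc(-c2nc(N(C)C)sc2-c2ccc(C)cc2)cc(OC)c1OC`, gives 3480 nM.

Compound 4, `COc1cc(-c2nc(N(C)C)sc2-c2ccc(C(F)(F)F)cc2)cc(OC)c1OC`, has not been measured yet. It differs from compound 3 by trifluoromethyl in place of methyl on an aromatic carbon. This very change has been made once before, from compound 1 to compound 2, where it reads trifluoromethyl in place of methyl on an aromatic carbon at the same place and produced a 180-fold higher number from compound 1 to compound 2 (2.24 log units; beyond the scatter). The cores of compound 1 and compound 3 differ by methyl in place of hydrogen on a nitrogen on an aromatic ring, a change that on its own gave a 190-fold higher number from compound 1 to compound 3 (2.28 log units; beyond the scatter). Compound 3 therefore sits far from compound 1 already, with a value within the scatter of compound 2. Because the earlier instance gave a 180-fold higher number from compound 1 to compound 2 (2.24 log units; beyond the scatter), a further large loss is expected for compound 4 when the same change is applied to the core of compound 3, though it rests on a single prior example and the assay may only report a limit that high. The step from compound 3 to compound 4 is expected to be a 17-fold higher number from compound 3 to compound 4 (1.24 log units; beyond the scatter). Compound 4 is estimated at 60000 nM, expected to fall between 10000 nM and 300000 nM.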

Compound 4, half-maximal inhibitory concentration: > 10000 nM
Compound 4 gave a limit, no number; the forecaster's own chance of this, stated with the estimate: 40%; the middle value does not contradict the limit.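

In this assay compound 4 gives > 10000 nM, which is a limit of the assay and not a number. Putting trifluoromethyl in place of methyl gives an at least 2.8-fold higher number from compound 3 to compound 4 (0.45 log units; beyond the scatter), so the change raises the number on this core too, as it did on the core of compound 1, but its size cannot be said to carry over: the same change on two cores in this assay, a 180-fold higher number (2.24 log units; beyond the scatter) from compound 1 to compound 2 and an at least 2.8-fold higher number (0.45 log units; beyond the scatter) from compound 3 to compound 4; the limit leaves it open whether they differ Adding a methyl on the nitrogen gives an at least 3.1-fold higher number from compound 2 to compound 4 (0.49 log units; beyond the scatter), so this change also keeps its direction in a second setting, with its size equally unsettled: the same change on two cores in this assay, a 190-fold higher number (2.28 log units; beyond the scatter) from compound 1 to compound 3 and an at least 3.1-fold higher number (0.49 log units; beyond the scatter) from compound 2 to compound 4; the limit leaves it open whether they differ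

The compounds shown leave open how a chlorine or an ethyl group would read in the place held by methyl or trifluoromethyl on the phenyl ring. Also open, going by these compounds, is how an ethyl group on the nitrogen, or a free amine there, would compare with the methylamino and dimethylamino compounds.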